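The source may hold more compounds than are shown below. What is called first, only, known or untested is meant among the compounds shown, and "the series" means these compounds.

Measured compounds in a functional assay on A549 cells (Homo sapiens) for antiproliferative activity, read by MTT assay, with a stated time of 72 h; on this read-out lower numbers stand for stronger inhibition and higher numbers for weaker inhibition:

Compound 1, `O=C1COc2ccc(-c3cnc(Cl)c(NS(=O)(=O)c4ccc(F)cc4)c3)cc2N1C1CCCCC1`, gives 37900 nM.
Compound 2, `O=C1COc2ccc(-c3cnc(Cl)c(NS(=O)(=O)c4ccc(F)cc4)c3)cc2N1c1ccc(Cl)cc1`, gives 21600 nM.
Compound 3, `CC(C)N1C(=O)COc2ccc(-c3cnc(Cl)c(NS(=O)(=O)c4ccc(F)cc4)c3)cc21`, gives 5100 nM.

All three share one core and differ only in the group on the amide-type nitrogen in the ring. Compound 3 stands lowest of the three; its nearest neighbour is compound 2, with a 4.2-fold lower number from compound 2 to compound 3 (0.63 log units; beyond the scatter), and the furthest is compound 1, with a 7.4-fold lower number from compound 1 to compound 3 (0.87 log units; beyond the scatter). The two aryl-bearing and cyclohexyl-bearing compounds lie close to each other, as a 1.8-fold lower number from compound 1 to compound 2 (0.24 log units; within the scatter) shows.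

Compound 4, `O=C1COc2ccc(-c3cnc(Cl)c(NS(=O)(=O)c4ccc(F)cc4)c3)cc2N1`, is not yet measured. It differs from compound 3 by hydrogen in place of isopropyl on an amide-type nitrogen in a ring. Within the data shown here, the steps that bear on this change are those in which the group on the same nitrogen was exchanged, namely from compound 1 and from compound 2 to compound 3, both modest and both beyond the scatter. Among the measured compounds shown here, no measured step, however, removes the group entirely, so the direction of this further exchange is not fixed by the data. Compound 4 is therefore expected to stay near compound 3, with a step of a 1.4-fold higher number from compound 3 to compound 4 (0.14 log units; within the scatter), and its estimated value in this assay is 7000 nM, within a range from 1800 nM to 28000 nM.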

Compound 4, half-maximal inhibitory concentration: > 40000 nM
Compound 4 ended at the assay's limit; the forecaster's own chance of this, stated with the estimate: 5%; middle value at least 5.7-fold (0.75 log units) from the limit.
By their numbers in this assay, from the lowest: compound 3; then compounds 2 and 1 (each within the scatter of the next). At a limit, above all of these: compound 4.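

In this assay compound 4 stands at a limit of the assay and not at a number: the limit of > 40000 nM in this assay, at which 1 of the 4 values shown sits. Even so, hydrogen in place of isopropyl on the amide-type nitrogen in the ring is a step beyond the scatter, an at least 7.8-fold higher number from compound 3 to compound 4 (0.89 log units; beyond the scatter), so a bare nitrogen here does not keep the level of compound 3, and a group on this nitrogen matters in both directions: hydrogen, cyclohexyl and 4-chlorophenyl all give higher numbers than isopropyl. The other two steps give only floors within the scatter, an at least 1.8-fold higher number from compound 2 to compound 4 (0.26 log units; that floor lies within the scatter) and an at least 1.0-fold higher number from compound 1 to compound 4 (0.02 log units; that floor lies within the scatter), so these leave no order among the three compounds concerned.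

On these data alone, whether a methyl or ethyl group on this nitrogen would go lower than isopropyl stays open. So does the effect of a longer chain ending in an amine or a carboxylic acid.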